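Cytotoxicity notes on a four-compound series

The compounds below may be only part of what the source reports. "The series", "measured", "known", "first", "only" and "open" are said of these compounds alone.

Compound 1 `CC1=CC(C)(C)N(Cc2ccc(Cl)cc2)c2ccc(O)cc21` and compound 2 `CC1=CC(C)(C)N(Cc2ccc(C)cc2)c2ccc(O)cc21` share one core with a free hydroxyl and differ only in the group on the pendant ring. In an ADME assay on L6 cells (Rattus norvegicus) for cytotoxicity, read by resazurin assay, with a stated time of 70 h (on this read-out higher numbers stand for weaker inhibition and lower numbers for stronger inhibition), compound 1 gives 7900 nM. In this assay compound 2 gives 8100 nM. The change between them is methyl in place of chloro on an aromatic carbon, and it produces a 1.0-fold higher number from compound 1 to compound 2 (0.01 log units; within the scatter).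

Compound 3 `COc1cc(OC)cc(C(=O)Oc2ccc3c(c2)C(C)=CC(C)(C)N3Cc2ccc(Cl)cc2)c1` carries the 4-chlorobenzyl group on a core whose hydroxyl is esterified. In this assay compound 3 reaches only > 190000 nM, which is a limit of the assay and not a number (the limit of > 190000 nM in this assay, at which 1 of the 3 values shown sits). The difference between the core of compound 1 and the core of compound 3 is not broken down here.

Compound 4 `COc1cc(OC)cc(C(=O)Oc2ccc3c(c2)C(C)=CC(C)(C)N3Cc2ccc(C)cc2)c1` has not been measured in this assay. It differs from compound 3 by methyl in place of chloro on an aromatic carbon, the same change as from compound 1 to compound 2, at a place described in the same words. For compound 4 the step that the limit leaves unreadable from compound 3 to compound 4 is expected to be small, resting on a 1.0-fold higher number from compound 1 to compound 2 (0.01 log units; within the scatter). Compound 4 is therefore expected to give about 250000 nM, within 100000 nM to 700000 nM, most likely again only as a limit in this assay.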

Compound 4, half-maximal inhibitory concentration: > 200000 nM
Compound 4: only a limit was reported (the forecaster's own chance of this, stated with the estimate: 80%); the middle value lies beyond the limit too.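

In this assay, among the compounds shown here, compound 3 and compound 4 both stand only as limits of the assay and not as numbers, so no step between them can be read. The compounds shown leave open whether methyl in place of chloro on an aromatic carbon acts on the esterified core as it does on the core of compound 1.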